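Chloro for Methyl on a Diaminoquinazoline Core

The compounds below may be only part of what the source reports. "The series", "measured", "known", "first", "only" and "open" are said of these compounds alone.

Three compounds that share a core carrying two amino groups have been tested in an assay for inhibition of Dihydrofolate reductase (Rattus norvegicus); a lower number here means a stronger inhibitor, a higher number a weaker inhibitor. Compound 3 `Cc1cccc2nc(N)nc(N)c12` gives 813 nM, the lowest number of the three. Compound 1 `Nc1nc(N)c2c(/C=C\c3ccc4ccccc4c3)cccc2n1` gives 5250 nM, and compound 2 `Nc1nc(N)c2c(S(=O)(=O)c3ccc(Cl)c(Cl)c3)cccc2n1` gives 57500 nM; both gaps to compound 3 lie beyond the usual scatter, so compound 3 is the strongest inhibitor of the measured set.

Compound 4 `Nc1nc(N)c2c(Cl)cccc2n1` has not yet been measured. It differs from compound 3 in one place: chloro in place of methyl on an aromatic carbon. Among the measured compounds shown here, no pair of measured compounds shows this exchange, so the data themselves say nothing about its effect. The expected step from compound 3 to compound 4 in this assay is small, either within the scatter or a modest move toward a lower number, with an estimated shift of a 1.6-fold lower number from compound 3 to compound 4 (0.21 log units; within the scatter). Compound 4 is therefore expected to give about 500 nM, with a likely range from 150 nM to 2000 nM.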

Compound 4, half-maximal inhibitory concentration: 562 nM
Beside the measured number, compound 4's estimate is 1.1-fold (0.05 log units) below it, and the stated range covers the measured number.
By their numbers in this assay, from the lowest: compounds 4 and 3 (each within the scatter of the next); then compound 1; then compound 2.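

Before this result, no two measured compounds differed in only one place, so nothing could be read directly about a change at this aromatic carbon. In this assay, chloro in place of methyl now gives a 1.4-fold lower number from compound 3 to compound 4 (0.16 log units; within the scatter), so this single pair does not separate the two groups at this position. The data shown offer no evidence on why the exchange has so little effect on the number.

On these data alone, it remains open whether other small groups at this position, such as a bromine atom, a methoxy group or an amine, would also stay this close to compound 3 or would move the number beyond the scatter. One pair also cannot show whether chloro in place of methyl would behave the same way elsewhere on the shared core.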